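Swapping the Imide Substituent: Pyridinyl Out, Chlorophenyl In

The source may report more compounds than this note shows. Statements on the series, on what has been measured and on what is new or still open speak of the compounds shown alone.

Compound 1 `Cn1cc(C2=C(c3n[nH]c4ncccc34)C(=O)NC2=O)c2ccccc21` — in a functional assay on K562 cells (Homo sapiens) for antiproliferative activity, read by MTT assay, with a stated time of 48 h (on this read-out lower numbers stand for stronger inhibition and higher numbers for weaker inhibition), compound 1 gives > 100000 nM, a limit of the assay.
Compound 2 `CN(C)CCCn1nc(C2=C(c3cn(C)c4ccccc34)C(=O)NC2=O)c2cccnc21` — in this assay compound 2 gives 50400 nM.
Compound 3 `Cn1cc(C2=C(c3nn(CCCN4CCCCC4)c4ncccc34)C(=O)N(c3ccccn3)C2=O)c2ccccc21` — in this assay compound 3 gives > 100000 nM, a limit of the assay.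

Compound 3 therefore stands at the limit of > 100000 nM in this assay, at which 2 of the 3 values shown sit, not at a number. Compound 4 `Cn1cc(C2=C(c3nn(CCCN4CCCCC4)c4ncccc34)C(=O)N(c3ccc(Cl)cc3)C2=O)c2ccccc21` differs from compound 3 in one place: 4-chlorophenyl in place of pyridin-2-yl on an amide-type nitrogen in a ring. The only measured step, an at least 1.9-fold lower number from compound 1 to compound 2 (0.29 log units; that floor lies within the scatter), concerns a different position and does not bear on this change, and no other comparison at the amide-type nitrogen exists among the compounds shown. Hence no step beyond the scatter is expected, and the estimated step that the limit leaves unreadable from compound 3 to compound 4 reflects that. Compound 4 is expected at 120000 nM, within a range from 40000 nM to 400000 nM, and most likely reported again only as a limit.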

Compound 4, half-maximal inhibitory concentration: 1800 nM
The estimate for compound 4 lay 67-fold (1.82 log units) above the measured number; the measured number lies below the stated range.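

At the amide-type nitrogen in the ring, 4-chlorophenyl in place of pyridin-2-yl brings an at least 55-fold lower number from compound 3 to compound 4 (1.74 log units; beyond the scatter) in this assay, which shows that the read-out responds strongly to the group at this position, something the earlier step, at a different position, could not show. The size of this step is only a floor, and compound 3 stands at a limit: the limit of > 100000 nM in this assay, at which 2 of the 4 values shown sit.

The compounds shown leave open whether the chlorine or the replacement of the ring nitrogen by carbon accounts for the step. A plain phenyl or a 4-methoxyphenyl at this nitrogen would separate the two.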